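Aminopyridyl to Aminophenyl: Expecting Another Cytotoxicity Limit

This account rests on a few compounds, and the source may have more. Where it says the series, first, only, none or still open, it means among the compounds named here.

Two compounds that share a core built from a fused system of two rings have been tested in a functional assay on RD cells (Homo sapiens) for inhibition, read by luminescence and ATP content, with a stated time of 72 h; on this read-out lower numbers stand for higher toxicity in this test and higher numbers for lower toxicity in this test. Compound 1 `CCOC(=O)c1cnc2ccc(-c3cccc(N)c3)cc2c1` carries a 3-aminophenyl group on that core. In this assay compound 1 gives > 7400 nM, which is a limit of the assay rather than a number. Compound 2 `CCc1nc(-c2cnc3ccc(-c4ccc(N)nc4)cc3c2)no1` differs from compound 1 elsewhere on the core and carries a 6-aminopyridin-3-yl group. In this assay compound 2 gives > 66700 nM, again a limit rather than a measured number. Among the compounds with values here, compound 2 therefore stands at the limit noted in the limit of > 66700 nM in this assay, at which 1 of the 2 values shown sits, and compound 1 at the one in the limit of > 7400 nM in this assay, at which 1 of the 2 values shown sits; no step between measured compounds can be computed.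

Compound 3 `CCc1nc(-c2cnc3ccc(-c4cccc(N)c4)cc3c2)no1` has not yet been measured. It differs from compound 2 by 3-aminophenyl in place of 6-aminopyridin-3-yl on an aromatic carbon. Compound 1 carries the same 3-aminophenyl group and also stands at a limit. The step from compound 2 to compound 3 in this assay is expected to be none beyond the scatter, an at least 1.1-fold lower number from compound 2 to compound 3 (0.04 log units; that floor lies within the scatter). Compound 3 is estimated at 60000 nM, between 15000 nM and 200000 nM, and most likely only a limit will be reported.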

Compound 3, half-maximal cytotoxic concentration: > 7400 nM
Compound 3 gave a limit, no number (the forecaster's own chance of this, stated with the estimate: 80%); the middle value does not contradict the limit.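

Compound 1, compound 2 and compound 3 each give only a limit of the assay in this assay, not a number, so no step can be read from compound 2 to compound 3 or from compound 1 to compound 3. The compounds shown leave open whether 3-aminophenyl in place of 6-aminopyridin-3-yl, or 5-ethyl-1,2,4-oxadiazol-3-yl in place of ethoxycarbonyl, changes toxicity in this test at all.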